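Replacing cyano with carbamoyl in a non-toxic series

The source may report more compounds than this note shows. Statements on the series, on what has been measured and on what is new or still open speak of the compounds shown alone.

Measured in an ADME assay on HEK293 cells (Homo sapiens) for cytotoxicity, with a stated time of 72 h; on this read-out lower numbers stand for an effect already at smaller amounts and higher numbers for an effect only at larger amounts of compound:
Compound 1 `C=C[C@@](C)(/C=C/c1ccc(O)cc1)CC/C=C/C#N` gives > 36600 nM, a limit.
Compound 2 `C=C[C@@](C)(/C=C/c1ccc(O)c(/C=C/C#N)c1)CCC=C(C)C` gives > 36600 nM, a limit.

Neither compound yields a number, so the data offer a ceiling rather than a ranking. Compound 2 stands at the limit of > 36600 nM in this assay, at which 2 of the 2 values shown sit, and compound 1 shares that position. Going by the values given here, no step between measured compounds is available to guide the next comparison.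

Compound 3 `C=C[C@@](C)(/C=C/c1ccc(O)c(/C=C/C(N)=O)c1)CCC=C(C)C` differs from compound 2 in one place: carbamoyl in place of cyano on a double-bonded chain carbon bound to a double-bonded chain carbon. The rest of the structure is unchanged.

With only the limit of compound 2 at > 36600 nM to go on, no shift beyond the usual scatter is expected in this assay, in either direction. The estimated step that the limit leaves unreadable from compound 2 to compound 3 is correspondingly small. Compound 3 is expected to give about 40000 nM, with an estimated range of 20000 nM to 70000 nM.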

Compound 3, half-maximal effective concentration: > 36600 nM
Compound 3 gave a limit, no number (the forecaster's own chance of this, stated with the estimate: 85%); the middle value is on the limit's open side.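

Compound 2 and compound 3 both end at a limit in this assay, and the step between them cannot be read. The compounds shown leave open the concentration at which any of them would reach a half-maximal effect, and whether cyano and carbamoyl differ there at all.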